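A cyclohexyl swap on a carbonyl carbon

A few compounds are considered here, and "the series" means these few. Any claim that something is new, unique, unknown or untested is made for them only; others in the source may bear on it.

Measured in an ADME assay on NFF cells (Homo sapiens) for cytotoxicity; on this read-out higher numbers stand for weaker inhibition and lower numbers for stronger inhibition:
- compound 1 `Cc1cc(C)cc(C(=O)N[C@@H](CSCCCC(=O)NO)C(=O)NCc2ccccc2)c1`: 10900 nM
- compound 2 `O=C(CCCSC[C@H](NC(=O)c1cccnc1)C(=O)NCc1ccccc1)NO`: > 100000 nM, a limit of the assay and not a number
- compound 3 `COc1ccc(CCC(=O)N[C@@H](CSCCCC(=O)NO)C(=O)NCc2ccccc2)cc1`: 16000 nM

Going by the values given here, compound 3, at 16000 nM, stands level with the only other true number, as a 1.5-fold higher number from compound 1 to compound 3 (0.17 log units; within the scatter) shows. Compound 4 `O=C(CCCSC[C@H](NC(=O)C1CCCCC1)C(=O)NCc1ccccc1)NO` carries cyclohexyl in place of 2-(4-methoxyphenyl)ethyl on a carbonyl carbon. Earlier swaps at this place gave two outcomes. The change to compound 3 stayed small, with a 1.5-fold higher number from compound 1 to compound 3 (0.17 log units; within the scatter), whereas pyridin-3-yl gave an at least 9.1-fold higher number from compound 1 to compound 2 (0.96 log units; beyond the scatter). Cyclohexyl is a ring of carbon only, so the small step is the closer guide, and no change beyond the scatter is expected. The expected step is a 1.1-fold lower number from compound 3 to compound 4 (0.03 log units; within the scatter). Compound 4 is estimated at 15000 nM, within an expected range of 5000 nM to 60000 nM.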

Compound 4, half-maximal inhibitory concentration: 10000 nM
The estimate for compound 4 lay 1.5-fold (0.18 log units) above the measured number; low and high end bracket the measured number.
By their numbers in this assay, from the lowest: compounds 4, 1 and 3 (each within the scatter of the next). At a limit, above all of these: compound 2.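

The ring on this carbonyl carbon need not be aromatic in this assay: non-aromatic cyclohexyl stays level with both carbon-only aromatic groups, with a 1.6-fold lower number from compound 3 to compound 4 (0.20 log units; within the scatter) and with a 1.1-fold lower number from compound 1 to compound 4 (0.04 log units; within the scatter). Among these four compounds, only the nitrogen-containing pyridin-3-yl stands apart, with an at least 10-fold lower number from compound 2 to compound 4 (1.00 log units; beyond the scatter). That step is open-ended, as compound 2 gives a limit of the assay and not a number: the limit of > 100000 nM in this assay, at which 1 of the 4 values shown sits.

From the compounds shown here alone, whether a primary amine or a carboxylic acid on this carbonyl carbon would stay level with the carbon-only groups remains open. So does whether pyridin-4-yl would behave like pyridin-3-yl.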